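Amide aryl exchange: compound 3 to compound 4

The compounds below may be only part of what the source reports. "The series", "measured", "known", "first", "only" and "open" are said of these compounds alone.

Measured compounds:
compound 1 `CCCN(CC[C@H]1CC[C@H](NC(=O)/C=C/c2cccc(F)c2)CC1)[C@H]1CCc2nc(N)sc2C1` — 9.9 nM
compound 2 `CCCN(CC[C@H]1CC[C@H](NC(=O)c2cccc3cnccc23)CC1)[C@H]1CCc2nc(N)sc2C1` — 5.9 nM
compound 3 `CCCN(CC[C@H]1CC[C@H](NC(=O)c2ccccc2-n2cccn2)CC1)[C@H]1CCc2nc(N)sc2C1` — 2 nM

All three share one core and differ only in the group on the amide carbonyl carbon. In an assay on brain for displacement of a labelled ligand from D(3) dopamine receptor (Rattus norvegicus) (on this read-out higher numbers stand for weaker inhibition and lower numbers for stronger inhibition), compound 3 gives the lowest number of the three: the step of a 5.0-fold lower number from compound 1 to compound 3 (0.69 log units; beyond the scatter) and the step of a 3.0-fold lower number from compound 2 to compound 3 (0.47 log units; beyond the scatter) are both beyond the scatter, while a 1.7-fold lower number from compound 1 to compound 2 (0.22 log units; within the scatter) is not. Compound 4 `CCCN(CC[C@H]1CC[C@H](NC(=O)c2cccc(-n3ccnc3)c2)CC1)[C@H]1CCc2nc(N)sc2C1` is not yet measured; its change from compound 3 is 3-(1H-imidazol-1-yl)phenyl in place of 2-(1H-pyrazol-1-yl)phenyl on a carbonyl carbon. Among the measured compounds shown here, no measured step rearranges the same atoms in this way, so the only guidance comes from the three amide-group exchanges, each of which moved the number by a modest amount at most. On that basis compound 4 is expected to land within the span covered by the measured compounds, most likely somewhat weaker than compound 3 rather than stronger. For compound 4 the estimate in this assay is 4 nM with a range of 1.5 nM to 12 nM. This estimate corresponds to an expected step of a 2.0-fold higher number from compound 3 to compound 4 (0.30 log units; within the scatter).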

Compound 4, inhibition constant: 1.1 nM
For compound 4 the middle estimate is 3.6-fold (0.56 log units) above the measured one; measured number below the stated range.
By their numbers in this assay, from the lowest: compounds 4 and 3 (each within the scatter of the next); then compounds 2 and 1 (each within the scatter of the next).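

In this assay, the exchange of 2-(1H-pyrazol-1-yl)phenyl for 3-(1H-imidazol-1-yl)phenyl on the carbonyl carbon joins the same atoms differently and gives a 1.8-fold lower number from compound 3 to compound 4 (0.26 log units; within the scatter), so this position accepts that rearrangement without a readable change. The new group also keeps the separation from the other two amide groups, with a 5.4-fold lower number from compound 2 to compound 4 (0.73 log units; beyond the scatter) and a 9.0-fold lower number from compound 1 to compound 4 (0.95 log units; beyond the scatter). No measured property or other supporting data at hand accounts for these steps.

Among the compounds shown here, the single exchange alters both the five-membered ring and its attachment to the phenyl ring, so the contribution of each remains unresolved. Also open, on these data alone, is how this assay would respond to an amine or a carboxylic acid on that phenyl ring.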